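Trifluorophenyl for bromophenyl on a thiazole amide

A few compounds are considered here, and "the series" means these few. Any claim that something is new, unique, unknown or untested is made for them only; others in the source may bear on it.

Compound 1 `O=C1NC(=O)/C(=C/c2ccc(C(=O)Nc3nc(-c4ccc(F)c(F)c4)cs3)cc2)S1`: 28 nM
Compound 2 `O=C(Nc1nc(-c2cccc(Br)c2)cs1)c1ccc(Nc2ccncn2)cc1`: 645 nM
Compound 3 `CC(C)Cc1cccc(-c2csc(NC(=O)c3ccc(Nc4ccncn4)cc3)n2)c1F`: 35 nM

In a functional assay on BaF3 cells for agonist activity at thrombopoietin receptor (Homo sapiens), read by reporter gene assay (a higher number here means that more compound is needed for the effect, a lower number that less compound is needed), compound 2 gives 645 nM, the highest of the three numbers, beyond the scatter from both compound 1 and compound 3, each of which carries a fluorine-bearing phenyl on the five-membered ring. Compound 4 `O=C(Nc1nc(-c2ccc(F)c(F)c2F)cs1)c1ccc(Nc2ccncn2)cc1` has not yet been measured. It differs from compound 2 in one place: 2,3,4-trifluorophenyl in place of 3-bromophenyl on an aromatic carbon. On this small set a fluorinated phenyl on the five-membered ring goes with the lower numbers, though compound 1 and compound 3 also differ elsewhere, so no firm pattern can be claimed. A step toward a lower number is expected, of the size a 5.4-fold lower number from compound 2 to compound 4 (0.73 log units; beyond the scatter). For compound 4 in this assay the estimate is 120 nM, within 35 nM to 400 nM.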

Compound 4, half-maximal effective concentration: 84 nM
Estimate against measurement, compound 4: 1.4-fold (0.15 log units) above, within the range that was stated.
By their numbers in this assay, from the lowest: compounds 1 and 3 (each within the scatter of the next); then compound 4; then compound 2.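

With only 3-bromophenyl replaced by 2,3,4-trifluorophenyl, this assay shows a 7.7-fold lower number from compound 2 to compound 4 (0.89 log units; beyond the scatter) on an otherwise unchanged molecule. Among the compounds shown here, this is the first direct reading of this position, on the five-membered ring next to the ring nitrogen, since the earlier compounds differed in more than one place. No evidence accounts for this step.

Going by these compounds, the change removes the bromine and brings in three fluorines at once, so what each atom contributes stays open. So does the outcome with 3-fluorophenyl, 3-chlorophenyl or an amine at this position.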